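Fluorophenyl for Cyanophenyl on a Quinolinyl Pyridinecarboxamide

The source may hold more compounds than are shown below. What is called first, only, known or untested is meant among the compounds shown, and "the series" means these compounds.

Measured compounds:
compound 1 `N#Cc1ccc(-c2ccc(C(=O)Nc3ccc4cccnc4c3)cn2)cc1`, < 6.6
compound 2 `Cc1cc(-c2ccccc2)ncc1C(=O)Nc1ccc2cccnc2c1`, 6.7

Compound 1 sits at a limit in an in vitro functional assay on 1321-N1 cells for antagonist activity at transient receptor potential cation channel subfamily V member 1 (Homo sapiens), read by FLIPR and calcium flux; a lower number here means a less potent compound, a higher number a more potent compound, by a factor of ten per unit of this negative logarithm: the value < 6.6 is a limit of the assay and not a number, (the limit of < 6.6 in this assay, at which 1 of the 2 values shown sits). Compound 2 shares the amide and the quinolinyl part but carries a different pyridine substitution and a plain phenyl ring, and in this assay compound 2 gives 6.7.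

The unmeasured compound 3 `O=C(Nc1ccc2cccnc2c1)c1ccc(-c2cccc(F)c2)nc1` differs from compound 1 by 3-fluorophenyl in place of 4-cyanophenyl on an aromatic carbon. Among the compounds with values here, since compound 1 stands only at a limit, no measured step fixes the size of this change. Compound 3 is expected to land near the value of compound 2, which gives 6.7 with an unsubstituted phenyl ring, so the step from compound 1 is estimated as a number at least 0.20 log units higher from compound 1 to compound 3 (that floor lies within the scatter), beyond the scatter in the direction of higher potency. Compound 3 is thus expected at 6.8, in the range 6.2 to 7.4.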

Compound 3, negative logarithm of the antagonist equilibrium constant: 8.6
For compound 3 the middle estimate is 1.80 log units below the measured one; the measured number lies above the stated range.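

At the aromatic carbon next to the ring nitrogen, replacing 4-cyanophenyl with 3-fluorophenyl gives a number at least 2.00 log units higher from compound 1 to compound 3 (beyond the scatter) in this assay, so the aryl group at this one place can carry a large change in potency. Compound 1 stands at < 6.6, which is a limit of the assay and not a number. The step is therefore a floor, and its full size stays unknown: the limit of < 6.6 in this assay, at which 1 of the 3 values shown sits.

The compounds shown do not separate what losing the nitrile contributes from what gaining the fluorine contributes, as the two rings differ in both the group and its place on the ring. From the compounds shown here alone, it also remains open whether a methoxy group or an amine on that phenyl ring would keep compound 3 at 8.6.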